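Methoxy for Methyl on the Aryl Arm of a Pyrazole Core

The source may hold more compounds than are shown below. What is called first, only, known or untested is meant among the compounds shown, and "the series" means these compounds.

Measured so far:
Compound 1, `COc1ccc(-c2nn(-c3ccc(Cl)cc3)cc2C=O)cc1`: 57.6%
Compound 2, `Cc1ccc(-c2nn(-c3ccc(Cl)cc3)cc2/C=N\c2ccc(Cl)cc2)cc1`: 49.2%

Both compounds were tested in a functional assay on the whole organism (strain Wistar albino) for inhibition, with Rattus norvegicus as the target, read by paw edema, with stated times of 1 h and 3 h, at a dose of 0.32 mmol/kg by the intraperitoneal route; a higher number here means more inhibition at the dose given (going by the name of the read-out), a lower number less inhibition. Of the two numbers, compound 2 gives the smaller one, but the gap to compound 1 lies within the usual scatter of repeated measurements, so the two cannot be told apart on this evidence.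

The next compound, compound 3 `COc1ccc(-c2nn(-c3ccc(Cl)cc3)cc2/C=N\c2ccc(Cl)cc2)cc1`, differs from compound 2 in one place: methoxy in place of methyl on an aromatic carbon. Among the measured compounds shown here, no pair of measured compounds shows this same change on its own, so its effect on paw edema inhibition has not been seen here. Compound 1 does carry the methoxy group, yet it differs from compound 2 in a second place as well, so its value alone cannot be pinned to the methyl-to-methoxy exchange.

For the measured compounds named here, with no measured step to lean on, the expected step in this assay is none beyond the scatter, in either direction. Compound 3 is therefore estimated to give 52%, within a range of 40% to 65%. That estimate means an expected change of a number 2.8 percentage points higher from compound 2 to compound 3 (within the scatter).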

Compound 3, a percentage reported as inhibition, in the whole organism at one dose (the size of the read-out at that dose, not a potency): 72.6%
The estimate for compound 3 lay 20.6 percentage points below the measured number; measured number outside the range, above it.
By their numbers in this assay, from the lowest: compounds 2 and 1 (each within the scatter of the next); then compound 3.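

In this assay, the exchange of methyl for methoxy on the aromatic carbon para to a large group can now be read on its own, as a number 23.4 percentage points higher from compound 2 to compound 3 (beyond the scatter), so this single change moves the read-out beyond the scatter. Compounds 1 and 2 could not show this, since they differ in two places. With methoxy held fixed, a second place matters too: a larger group carrying a six-membered aromatic ring in place of the carbonyl group of compound 1 gives a number 15 percentage points higher from compound 1 to compound 3 (beyond the scatter), yet no measurement at hand accounts for either step.

Going by these compounds, the methyl-to-methoxy step rests on one pair of compounds, so it remains open whether the same exchange would matter as much in a compound that keeps the carbonyl group of compound 1. On these data alone, it is also open whether the oxygen or the longer reach of the group goes with the higher number, a question that a hydroxyl, an ethoxy or a dimethylamino group at the same place could help to answer.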